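This account rests on a few compounds, and the source may have more. Where it says the series, first, only, none or still open, it means among the compounds named here.

- compound 1 `CCCCCCCNC[C@@H]1OC[C@H](N)[C@@H]1O` gives 22400 nM
- compound 2 `CCCCCCCCCCCCNC[C@@H]1OC[C@H](N)[C@H]1O` gives 2380 nM
- compound 3 `CCCCCCCCCCCCNC[C@@H]1OC[C@H](N)[C@@H]1O` has not yet been measured

In a functional assay on PC-3 cells (Homo sapiens) for antiproliferative activity, read by MTT assay, with a stated time of 72 h (a lower number here means a stronger inhibitor, a higher number a weaker inhibitor), compound 2 holds the lower of the two numbers, at 2380 nM, a gap beyond the scatter from compound 1. Compound 3 has the same atoms and bonds as compound 2 and differs only in configuration as drawn: the two compounds have the same atoms and bonds and differ only in configuration as drawn: 1 of 3 stereo elements differ; a stereocentre at a saturated ring carbon is drawn R in compound 2 and S in compound 3. Going by the values given here, no measured pair shows what such a change does in this assay, so only a small rise is expected, with no shift beyond the scatter, and the estimated move is a 1.3-fold higher number from compound 2 to compound 3 (0.10 log units; within the scatter). Compound 3 is expected at about 3000 nM, with an estimated range from 1200 nM to 8000 nM.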

Compound 3, half-maximal inhibitory concentration: 850 nM
Estimate against measurement, compound 3: 3.5-fold (0.55 log units) above, and the stated range ends above it.
By their numbers in this assay, from the lowest: compound 3; then compound 2; then compound 1.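

In this assay, changing the configuration at a single saturated ring carbon, with no atom or bond altered, gives a 2.8-fold lower number from compound 2 to compound 3 (0.45 log units; beyond the scatter), so that centre matters in this pair. With the configuration of compound 3 held, pentyl in place of hydrogen on a saturated chain carbon, seven bonds along the chain from an amine nitrogen, gives a 26-fold lower number from compound 1 to compound 3 (1.42 log units; beyond the scatter), the larger of the two steps. The first step has a single structural source: the fact that compounds 2 and 3 differ only in the configuration as drawn.

On these data alone, whether the same configuration preference holds with the shorter chain of compound 1, or at the other two stereo elements, remains open. So does the effect of a longer chain, or of an amide in place of the amine.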